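The source may report more compounds than this note shows. Statements on the series, on what has been measured and on what is new or still open speak of the compounds shown alone.

Among the compounds with values here, compound 3 `CC(C)CNC(C)(C)CC(=O)N[C@@H]1CCc2ccccc2N(Cc2ccc(-c3ccccc3-c3nn[nH]n3)cc2)C1=O` stands second highest of the three numbers so far in a functional assay on cells (Pituitary gland cell) with growth hormone secretagogue receptor type 1 (Rattus norvegicus) as the target; a lower number here means that less compound is needed, a higher number that more compound is needed for the effect: compound 3 gives 85 uM, while compound 1 `N[C@@H]1CCc2ccccc2N(Cc2ccc(-c3ccccc3-c3nn[nH]n3)cc2)C1=O` gives 9 uM and compound 2 `CC(C)(CC(=O)N[C@@H]1CCc2ccccc2N(Cc2ccc(-c3ccccc3-c3nn[nH]n3)cc2)C1=O)NCCN` gives 230 uM. Compound 4 `CC(C)(N)CC(=O)N[C@@H]1CCc2ccccc2N(Cc2ccc(-c3ccccc3-c3nn[nH]n3)cc2)C1=O` differs from compound 3 by hydrogen in place of isobutyl on an amine nitrogen. Within the data shown here, two measured steps bear on the change. Adding the whole side chain raised the number a 9.4-fold higher number from compound 1 to compound 3 (0.98 log units; beyond the scatter) and, with the other terminus, a 26-fold higher number from compound 1 to compound 2 (1.41 log units; beyond the scatter), so a smaller substituent at this amine tends toward compound 1; the step of a 2.7-fold lower number from compound 2 to compound 3 (0.43 log units; beyond the scatter) shows that the terminus alone matters modestly. A downward step is therefore expected for compound 4, estimated at a 3.4-fold lower number from compound 3 to compound 4 (0.53 log units; beyond the scatter), giving 25 uM with a range from 6 uM to 90 uM.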

Compound 4, concentration for half-maximal effect: 0.06 uM
Compound 4: the middle estimate sits 420-fold (2.62 log units) above what was measured; the whole stated range lies above it.
By their numbers in this assay, from the lowest: compound 4; then compound 1; then compound 3; then compound 2.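

In this assay, within the data shown here, substitution on this amine nitrogen proves far more costly than the earlier compounds showed, with a 1400-fold lower number from compound 3 to compound 4 (3.15 log units; beyond the scatter) on losing isobutyl and a 3800-fold lower number from compound 2 to compound 4 (3.58 log units; beyond the scatter) on losing 2-aminoethyl. The side chain itself does not raise the number: with this nitrogen unsubstituted, (2-amino-2-methylpropyl)carbonyl on the core of compound 1 gives a 150-fold lower number from compound 1 to compound 4 (2.18 log units; beyond the scatter) instead of the rises seen with compound 2 and compound 3. Nothing available explains the size of these steps. Still open, going by these compounds, is whether a methyl or ethyl on this nitrogen is already as costly as isobutyl, and whether a longer chain carrying the same amine keeps the low number of compound 4.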